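Cyclopropylcarbonyl to ethylcarbamoyl on the shared core

The source may report more compounds than this note shows. Statements on the series, on what has been measured and on what is new or still open speak of the compounds shown alone.

Working notes on a small set sharing one core. In an assay on membranes from CHO cells for displacement of a labelled ligand from adenosine receptor A1 (Homo sapiens), read by scintillation counting, with a stated time of 60 min, tested at 1 uM (on this read-out lower numbers stand for less inhibition and higher numbers for more inhibition at the one concentration tested (going by the name of the read-out)), compound 1 `CC1=C(C(=O)C2CC2)C(c2ccoc2)NC(=O)N1` gives 1%; compound 2 `CC1=C(C(=O)C2CC2)C(c2cccs2)NC(=O)N1` gives 1%; compound 3 `CC1=C(C(=O)C2CC2)C(c2ccsc2)NC(=O)N1` gives 2%. Compound 1 stands level with compound 2, the two together the lowest of the three numbers, and the step of a number 1 percentage points higher from compound 1 to compound 3 (within the scatter) is within the scatter, as are no change at the digits printed from compound 1 to compound 2 (within the scatter) and a number 1 percentage points higher from compound 2 to compound 3 (within the scatter). All three measured steps change only the aromatic group on the saturated ring carbon; none touches the carbonyl carbon.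

Compound 4 `CCNC(=O)C1=C(C)NC(=O)NC1c1ccoc1` differs from compound 1 in ethylamino in place of cyclopropyl on a carbonyl carbon. Within the data shown here, no measured step bears on this change, so the expectation rests only on the flat, low run of compound 1, compound 2 and compound 3 in this assay. No step beyond the scatter is expected in either direction. For compound 4 the estimate is 2%, with a range from -6% to 12%. The step this estimate means is a number 1 percentage points higher from compound 1 to compound 4 (within the scatter), expected to stay within the scatter.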

Compound 4, a percentage reported as inhibition, at one concentration (the size of the read-out at that concentration, not a potency): 1%
Compound 4: the middle estimate sits 1 percentage points above what was measured, and the stated range covers the measured number.
By their numbers in this assay, from the lowest: compounds 1, 2, 4 and 3 (each within the scatter of the next).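

In this assay, among these compounds, the replacement of cyclopropyl by ethylamino on a carbonyl carbon gives no change at the digits printed from compound 1 to compound 4 (within the scatter) and is the first reading at this position, since the earlier steps changed only the aromatic group. Neither the loss of the three-membered ring nor the entry of a hydrogen-bond donor separates the two compounds on this read-out, although a number this low leaves little room to register any loss. Nothing at hand offers an explanation for this result.

As far as these compounds go, whether a dimethylamino, a phenylamino or a longer alkyl chain on this carbonyl carbon would lift the number clear of the scatter remains open. Also open, from the compounds shown here alone, is whether ethylamino gives the same picture with thiophen-2-yl or thiophen-3-yl in place of furan-3-yl on the saturated ring carbon.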